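This account rests on a few compounds, and the source may have more. Where it says the series, first, only, none or still open, it means among the compounds named here.

Compound 1 `COC(=O)CCCNC(=O)CSC1=C(OC)C(=O)c2ccccc2C1=O` gives 24000 nM in a functional assay on HeLa cells (Homo sapiens) for cytotoxicity, read by MTT assay, with a stated time of 48 h (a lower number here means a stronger inhibitor, a higher number a weaker inhibitor), the lowest of the two numbers in this small set. Compound 3 `CC[C@H](C)[C@H](NC(=O)CSC1=CC(=O)c2cccc(OC)c2C1=O)C(=O)OC` gives 94500 nM in this assay, a gap beyond the scatter. Compound 2 `COC(=O)CNC(=O)CSC1=CC(=O)c2cccc(OC)c2C1=O` returns only a limit of this assay, > 100000 nM, which is the limit of > 100000 nM in this assay, at which 1 of the 3 values shown sits. Among the compounds with values here, the single measured step, an at least 1.0-fold lower number from compound 2 to compound 3 (0.02 log units; that floor lies within the scatter), stays within the scatter. Compound 4 `CC[C@H](C)[C@H](NC(=O)CSC1=C(OC)C(=O)c2ccccc2C1=O)C(=O)OC` differs from compound 1 by 1-(methoxycarbonyl)-2-methylbutyl in place of 3-(methoxycarbonyl)propyl on an amide-type nitrogen. Within the data shown here, the change carries the same sec-butyl branch as the measured step, but it also alters the ester-bearing chain itself, for which no measured step exists. The step is therefore expected to be a 1.3-fold higher number from compound 1 to compound 4 (0.10 log units; within the scatter), with no change beyond the scatter. Compound 4 is estimated at 30000 nM, within a range of 12000 nM to 80000 nM.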

Compound 4, half-maximal inhibitory concentration: 82000 nM
The estimate for compound 4 lay 2.7-fold (0.44 log units) below the measured number; the measured number lies above the stated range.
By their numbers in this assay, from the lowest: compound 1; then compounds 4 and 3 (each within the scatter of the next). At a limit, above all of these: compound 2.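

On the amide-type nitrogen, the side chain matters in this assay: 1-(methoxycarbonyl)-2-methylbutyl in place of 3-(methoxycarbonyl)propyl gives a 3.4-fold higher number from compound 1 to compound 4 (0.53 log units; beyond the scatter). Within the data shown here, this is the first step at this position to lie beyond the scatter, and it is modest in size. Nothing shown gives a reason for this step.

The change alters the branching and the ester-bearing chain together, and the compounds shown do not separate the two. Going by these compounds, how a carboxylic acid in place of the methyl ester, or an amine at the chain end, would read remains open.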